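This account rests on a few compounds, and the source may have more. Where it says the series, first, only, none or still open, it means among the compounds named here.

Working notes on the series.

Compound 1 `Cc1cccc(-c2ccc(OC[C@@H]3Cn4ccc(=O)nc4O3)cc2)c1C` carries the shared core with an unsubstituted six-membered ring bearing two nitrogens; in a functional assay on HEK293 cells for positive allosteric modulation of metabotropic glutamate receptor 2 (Homo sapiens), read by fluorescence and cAMP accumulation, with a stated time of 5 min (a lower number here means that less compound is needed, a higher number that more compound is needed for the effect), compound 1 gives 330 nM. Its number is the highest of the three measured. Compound 3 `Cc1cccc(-c2ccc(OC[C@@H]3Cn4c(C)cc(=O)nc4O3)cc2)c1C` gives 274 nM in this assay, a gap from compound 1 that lies within the scatter; compound 2 `CC1(C)CCc2cc(OC[C@@H]3Cn4ccc(=O)nc4O3)ccc21`, with a different aryl portion, gives 159 nM, a gap beyond the scatter.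

The step of interest is from compound 1 to compound 4 `Cc1cccc(-c2ccc(OC[C@@H]3Cn4cc(C)c(=O)nc4O3)cc2)c1C`: methyl in place of hydrogen on an aromatic carbon. Among the compounds with values here, the only measured step that bears on it is a 1.2-fold lower number from compound 1 to compound 3 (0.08 log units; within the scatter), where a methyl also enters the same ring of the core but at a different aromatic carbon; that step did not move the number beyond the scatter. Compound 2 adds nothing to this point, since it differs in another part of the molecule.

On this single precedent, no step beyond the scatter is expected for this assay. Compound 4 is therefore estimated at 300 nM, with a range of 140 nM to 650 nM, and the expected step of a 1.1-fold lower number from compound 1 to compound 4 (0.04 log units; within the scatter) is small.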

Compound 4, half-maximal effective concentration: 14 nM
The estimate for compound 4 lay 21-fold (1.33 log units) above the measured number; measured number below the stated range.
By their numbers in this assay, from the lowest: compound 4; then compounds 2, 3 and 1 (each within the scatter of the next, the first and the last beyond it).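

The methyl on this aromatic carbon, ortho to a group of 1 heavy atom and two atoms from the ring nitrogen, gives a 24-fold lower number from compound 1 to compound 4 (1.37 log units; beyond the scatter) in this assay and is thus a large step from a single added carbon. The same exchange at another aromatic carbon of that ring gives a 1.2-fold lower number from compound 1 to compound 3 (0.08 log units; within the scatter) and stays within the scatter, so in this pair the size of the step depends on which ring carbon carries the methyl, and the earlier step gave no warning of this. Nothing shown accounts for the size of the step at this carbon, and its origin remains unexplained.

From the compounds shown here alone, it remains open whether the step is specific to methyl or would also appear with ethyl, a chlorine atom, a methoxy group or a nitrile on the same carbon. Going by these compounds, it is equally open whether the methyl keeps this effect with the aryl portion of compound 2, and whether methyl groups on both ring carbons, those of compound 3 and compound 4 together, would add to it or cancel it.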